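Working notes: thiophen-2-yl in place of 4-bromophenyl

This account rests on a few compounds, and the source may have more. Where it says the series, first, only, none or still open, it means among the compounds named here.

In a functional assay on NCI-H23 cells (Homo sapiens) for inhibition, read by sulforhodamine B assay, with a stated time of 48 h, tested at 10 uM (on this read-out higher numbers stand for more inhibition at the one concentration tested (going by the name of the read-out) and lower numbers for less inhibition), the measured compounds give:
compound 1 `O=Cc1ccc(-c2cn3ccnc3c(-c3ccc4ncn(C5CCCCC5)c4c3)n2)cc1`: 54.5%
compound 2 `Clc1ccc(-c2cn3ccnc3c(-c3ccc4ncn(C5CCCCC5)c4c3)n2)cc1`: 4.11%
compound 3 `Brc1ccc(-c2cn3ccnc3c(-c3ccc4ncn(C5CCCCC5)c4c3)n2)cc1`: 8.38%

Compound 3 stands second highest of the three; its gap to compound 2, a number 4.3 percentage points higher from compound 2 to compound 3 (within the scatter), is within the scatter, while compound 1 lies far above it, a number 46.1 percentage points lower from compound 1 to compound 3 (beyond the scatter).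

Compound 4 `c1csc(-c2cn3ccnc3c(-c3ccc4ncn(C5CCCCC5)c4c3)n2)c1` differs from compound 3 by thiophen-2-yl in place of 4-bromophenyl on an aromatic carbon. Within the data shown here, no measured step swaps the whole aryl ring. Among the measured compounds shown here, the steps that bear on it are a number 50.4 percentage points lower from compound 1 to compound 2 (beyond the scatter) and a number 46.1 percentage points lower from compound 1 to compound 3 (beyond the scatter), both large, and the only high number in the set belongs to the compound carrying the formyl group. Compound 4 carries no formyl, so the expected step is a number 6.6 percentage points higher from compound 3 to compound 4 (within the scatter), within the scatter, with wide uncertainty. Compound 4 is estimated at 15%, range -5% to 45%.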

Compound 4, a percentage reported as inhibition, at one concentration (the size of the read-out at that concentration, not a potency): 5.95%
Compound 4: middle estimate off by 9.1 percentage points, on the high side; the range from low to high includes it.
By their numbers in this assay, from the lowest: compounds 2, 4 and 3 (each within the scatter of the next); then compound 1.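

With a number 2.4 percentage points lower from compound 3 to compound 4 (within the scatter) and a number 1.8 percentage points higher from compound 2 to compound 4 (within the scatter) in this assay, a five-membered thiophen-2-yl ring and the two halogenated phenyl rings cannot be told apart at this position. Only a number 48.6 percentage points lower from compound 1 to compound 4 (beyond the scatter) is large, so among these four compounds compound 1, with its 4-formylphenyl group, stands alone. Nothing available gives a cause for this result.

Open, as far as these compounds go, is whether a carboxylic acid or an amine in place of the formyl group on the phenyl ring would give a number like that of compound 1, and whether a formyl group on the thiophen-2-yl ring would do so.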